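The compounds below may be only part of what the source reports. "The series", "measured", "known", "first", "only" and "open" are said of these compounds alone.

For the measured compounds named here, in an assay on microsomes from intestine for inhibition of acyl-CoA:cholesterol acyltransferase (Oryctolagus cuniculus) (a higher number here means a weaker inhibitor, a lower number a stronger inhibitor), compound 2 `CCCCCCCCOC(=O)CC(=O)Nc1c(C(C)C)cccc1C(C)C` gives 260 nM, the lowest of the two numbers so far. Compound 1 `CCCCCCOC(=O)CC(=O)Nc1c(C(C)C)cccc1C(C)C` gives 810 nM. Going by the values given here, the only step bearing on the next change is a 3.1-fold lower number from compound 1 to compound 2 (0.49 log units; beyond the scatter), which added a much shorter group at a nearby position on the same chain. Compound 3 `CCCCCCCCCCCCCCCCCCOC(=O)CC(=O)Nc1c(C(C)C)cccc1C(C)C` differs from compound 2 by decyl in place of hydrogen on a saturated chain carbon, eight bonds along the chain from an oxygen next to a carbonyl group. Among the compounds with values here, a further lowering is expected, though with one short step as the only guide its size is uncertain; the expected step is a 1.7-fold lower number from compound 2 to compound 3 (0.24 log units; within the scatter). Compound 3 is therefore estimated at 150 nM, in the range 40 nM to 600 nM.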

Compound 3, half-maximal inhibitory concentration: 53 nM
Estimate against measurement, compound 3: 2.8-fold (0.45 log units) above; the range from low to high includes it.
By their numbers in this assay, from the lowest: compound 3; then compound 2; then compound 1.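

Extending the saturated chain by decyl still lowers the number in this assay (a 4.9-fold lower number from compound 2 to compound 3 (0.69 log units; beyond the scatter)), so the trend from the short step continues well past that first extension. Across the three compounds the order follows chain length, with none going against it, and the whole span is large (a 15-fold lower number from compound 1 to compound 3 (1.18 log units; beyond the scatter)). No measurement here accounts for this fall.
Still open, going by these compounds, is whether a longer chain lowers the number further or reverses the trend. Also open, on these data alone, is how a branched chain, or a chain ending in an amine or a carboxylic acid, behaves at this place.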